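This account rests on a few compounds, and the source may have more. Where it says the series, first, only, none or still open, it means among the compounds named here.

Compound 1 `CCn1c(=O)c2c(nc(Cc3ccccc3)n2C)n(Cc2ccco2)c1=O` and compound 2 `CCn1c(=O)c2c(nc(Cc3ccco3)n2C)n(Cc2ccco2)c1=O` share one core and differ only in the group on a saturated chain carbon bound to an aromatic carbon. In an assay on cell membranes for displacement of a labelled ligand from adenosine receptor A1 (Rattus norvegicus) (a higher number here means a weaker inhibitor, a lower number a stronger inhibitor), compound 1 gives 28.8 nM, and compound 2 gives 107 nM. The step of a 3.7-fold higher number from compound 1 to compound 2 (0.57 log units; beyond the scatter) leaves compound 2 with the highest of the two numbers seen so far, its nearest neighbour being compound 1.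

Compound 3 `CCn1c(=O)c2c(nc(Cc3cccs3)n2C)n(Cc2ccco2)c1=O` differs from compound 2 by thiophen-2-yl in place of furan-2-yl on a saturated chain carbon bound to an aromatic carbon. Going by the values given here, the only measured step at this place is the one from compound 1 to compound 2, which exchanged phenyl for furan-2-yl; no measured pair exchanges furan-2-yl for thiophen-2-yl, so that earlier step bears on the new one only by showing that this position tolerates a change of modest size. A modest step is therefore expected, most likely toward a lower number, with the estimate for compound 3 in this assay being 55 nM, between 18 nM and 170 nM, corresponding to an expected step of a 1.9-fold lower number from compound 2 to compound 3 (0.29 log units; within the scatter).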

Compound 3, inhibition constant: 102 nM
The estimate for compound 3 lay 1.9-fold (0.27 log units) below the measured number, and the stated range covers the measured number.
By their numbers in this assay, from the lowest: compound 1; then compounds 3 and 2 (each within the scatter of the next).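

In this assay, replacing furan-2-yl with thiophen-2-yl on a saturated chain carbon bound to an aromatic carbon gives a 1.0-fold lower number from compound 2 to compound 3 (0.02 log units; within the scatter) and so makes no readable difference, even though one ring holds oxygen and the other sulfur. Phenyl now stands apart from both five-membered rings: a 3.5-fold higher number from compound 1 to compound 3 (0.55 log units; beyond the scatter) is close in size to a 3.7-fold higher number from compound 1 to compound 2 (0.57 log units; beyond the scatter) and shows that the higher number on leaving phenyl is not peculiar to furan-2-yl. No measured evidence explains either step.

From the compounds shown here alone, it remains open whether a six-membered ring containing nitrogen, such as pyridin-2-yl, or a saturated ring, such as cyclohexyl, would give a number like that of phenyl or like those of the two five-membered rings. Going by these compounds, a simple amine or a longer chain at this place is equally open.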